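This account rests on a few compounds, and the source may have more. Where it says the series, first, only, none or still open, it means among the compounds named here.

Measured so far:
compound 1 `C#Cc1cn([C@@H]2O[C@H](CO)[C@@H](O)[C@H]2O)c2ncnc(C)c12` gives 1110 nM in a functional assay on HL-60 cells (Homo sapiens) for antiproliferative activity, read by XTT assay, with a stated time of 72 h; a lower number here means a stronger inhibitor, a higher number a weaker inhibitor.
compound 2 `COc1nc(N)nc2c1c(-c1ccccc1)cn2[C@@H]1O[C@H](CO)[C@@H](O)[C@H]1O` reaches only a limit of the assay, > 20000 nM, in this assay.
compound 3 `Cc1nc(N)c2c(-c3cccs3)cn([C@@H]3O[C@H](CO)[C@@H](O)[C@H]3O)c2n1` likewise reaches only a limit of the assay, > 20000 nM, in this assay.

Where compound 3 stands: it has no number of its own in this assay, only a limit, and it shares that position with one other value shown, since (the limit of > 20000 nM in this assay, at which 2 of the 3 values shown sit). Among the measured compounds shown here, compound 1 is the sole compound with a measured number. For the measured compounds named here, no pair of measured compounds differs in one place, so no measured step exists to size the influence of the group on the five-membered ring of the shared core.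

The step to compound 4 `Cc1nc(N)c2c(-c3ccoc3)cn([C@@H]3O[C@H](CO)[C@@H](O)[C@H]3O)c2n1` is a small exchange at that position: furan-3-yl in place of thiophen-2-yl on an aromatic carbon. Both compounds bearing an aromatic five-membered or six-membered group at this place, compound 2 and compound 3, stay at the limit of this assay, and the change keeps the size and the single hetero atom of the group. The expectation is therefore a step that the limit leaves unreadable from compound 3 to compound 4 of no size beyond the scatter, with compound 4 most probably reported again as a limit. Compound 4 is estimated to give about 25000 nM in this assay, within a range from 8000 nM to 80000 nM.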

Compound 4, half-maximal inhibitory concentration: > 20000 nM
Compound 4 ended at the assay's limit; the forecaster's own chance of this, stated with the estimate: 80%; the middle value does not contradict the limit.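

No step can be read from compound 3 to compound 4, since both stand only at a limit, not at a number: the limit of > 20000 nM in this assay, at which 3 of the 4 values shown sit.

The compounds shown leave open how far furan-3-yl and thiophen-2-yl actually differ on the shared core, and how much any group at this place changes antiproliferative activity.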